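The compounds below may be only part of what the source reports. "The series", "measured", "known", "first", "only" and "open" are said of these compounds alone.

The measured compounds:
compound 1, `CCCn1ccc2cc(-c3cccnc3)cc(Cl)c2c1=O`: 83%
compound 2, `CCCn1ccc2cc(-c3cn[nH]c3)cc(Cl)c2c1=O`: 65%

Among the compounds with values here, in a functional assay on CHO cells for agonist activity at metabotropic glutamate receptor 2 (Homo sapiens), read by GTPgammaS binding (a higher number here means a larger maximal response, a lower number a smaller maximal response), compound 1 gives 83%, the higher of the two numbers known so far. Within the data shown here, compound 2 gives 65% in this assay, and the single measured step, a number 18 percentage points lower from compound 1 to compound 2 (beyond the scatter), is a modest drop that comes with the exchange of one whole ring for another.

Compound 3, `CCCn1ccc2cc(-c3ccc(OC)nc3)cc(Cl)c2c1=O`, differs from compound 1 by methoxy in place of hydrogen on an aromatic carbon. Among the measured compounds shown here, no measured step touches this kind of change: the step from compound 1 to compound 2 replaces the ring itself rather than adding a group to it, so it offers no direct guidance here. With the ring of compound 1 kept and only a methoxy added, no step beyond the scatter is expected in this assay. Compound 3 is therefore estimated at 83%, with a range from 68% to 96%. The expected step is no change at the digits printed from compound 1 to compound 3 (within the scatter).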

Compound 3, largest response reached (Emax), in percent of the reference or control that the assay uses: 121%
Estimate against measurement, compound 3: 38 percentage points below; measured number outside the range, above it.
By their numbers in this assay, from the lowest: compound 2; then compound 1; then compound 3.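

In this assay, methoxy in place of hydrogen on an aromatic carbon, next to the ring nitrogen and para to a large group, gives a number 38 percentage points higher from compound 1 to compound 3 (beyond the scatter), a large step upward. The earlier pair exchanged one whole ring for another and could not show that this carbon accepts a group, or that keeping the ring of compound 1 and adding methoxy here moves the maximal response up rather than leaving it in place. Nothing measured here accounts for the size of this rise.

From the compounds shown here alone, whether the rise belongs to methoxy itself or would also come with an ethoxy group, an amine or a fluorine atom on the same carbon stays open. So does whether a methoxy group would have a similar effect on the ring of compound 2.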